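The source may report more compounds than this note shows. Statements on the series, on what has been measured and on what is new or still open speak of the compounds shown alone.

Compound 1, `CCCCNc1nc(N)nc2cccc(CCc3ccccc3)c12`, gives 0.47 uM in an ADME assay on HEK293 cells for agonist activity at Toll-like receptor 8 (Homo sapiens), read by a luciferase reporter, with a stated time of 6 h; a lower number here means that less compound is needed, a higher number that more compound is needed for the effect.
Compound 2, `CCCCNc1nc(N)nc2cccc(C(=O)NC)c12`, gives 0.39 uM in this assay.

On these two numbers compound 2 has the lower one, but the step of a 1.2-fold lower number from compound 1 to compound 2 (0.08 log units; within the scatter) is within the scatter, so the two compounds cannot be told apart on potency. Compound 3, `CCCCNc1nc(N)nc2cccc(C(=O)NC(C)C)c12`, is the next compound to be measured. It differs from compound 2 in one place: isopropyl in place of methyl on an amide-type nitrogen. Among the measured compounds shown here, the only measured step, from compound 1 to compound 2, swaps the group on the aromatic carbon itself and says nothing about what an alkyl group on the amide-type nitrogen does; no measured pair bears directly on the change from compound 2 to compound 3. With no guide of that kind, the expectation is that compound 3 stays close to compound 2, with a step of about a 1.3-fold higher number from compound 2 to compound 3 (0.11 log units; within the scatter) in this assay, well inside the scatter and in no firm direction. Compound 3 is therefore estimated at 0.5 uM, within a range from 0.15 uM to 1.6 uM.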

Compound 3, minimum effective concentration: 15.6 uM
Compound 3: middle estimate off by 31-fold (1.49 log units), on the low side; the whole stated range lies below it.
By their numbers in this assay, from the lowest: compounds 2 and 1 (each within the scatter of the next); then compound 3.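

Among the compounds shown here, putting isopropyl in place of methyl on the amide-type nitrogen gives a 40-fold higher number from compound 2 to compound 3 (1.60 log units; beyond the scatter) in this assay, so the alkyl group on this nitrogen has a large effect on how much compound is needed, something the earlier compounds could not reveal. Compound 1 and compound 2 carry very different groups on the aromatic carbon yet lie within the scatter of each other, which might suggest that this carbon accepts almost anything, but the isopropylcarbamoyl group gives a 33-fold higher number from compound 1 to compound 3 (1.52 log units; beyond the scatter) and shows that it does not. No measurement here explains why so modest a change in the alkyl group has so large an effect.

The compounds shown leave open whether the number climbs gradually with the size of this alkyl group or jumps sharply, a question that an ethyl group on the same nitrogen would help to settle. They also leave open what a primary amide or a longer straight chain such as n-propyl would do, and so whether the branching of isopropyl or simply its added carbons matter more.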